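A few compounds are considered here, and "the series" means these few. Any claim that something is new, unique, unknown or untested is made for them only; others in the source may bear on it.

Measured compounds:
compound 1, `Cc1nc2sc(-c3ccccc3)nc2c(=O)[nH]1`, 85 nM
compound 2, `Cc1ccc(-c2nc3c(=O)[nH]c(C)nc3s2)cc1`, 33 nM
compound 3, `Cc1cccc(-c2nc3c(=O)[nH]c(C)nc3s2)c1`, 384 nM

All three share one core and differ only in a small group on the six-membered aromatic ring of carbon only. In an assay on CHO cells for displacement of a labelled ligand from adenosine receptor A3 (Homo sapiens), read by scintillation counting, with a stated time of 120 min (a higher number here means a weaker inhibitor, a lower number a stronger inhibitor), compound 3 gives 384 nM, the highest number of the three; its steps to compound 1 and compound 2 are both beyond the scatter, so compound 3 is the weakest inhibitor of the set. Compound 4 is `Cc1nc2sc(-c3cccc(Cl)c3)nc2c(=O)[nH]1`, not yet measured. The change is chloro in place of methyl on an aromatic carbon. Going by the values given here, no measured pair swaps a methyl for a chloro, so the step can only be judged indirectly. The two steps on record both add a methyl to compound 1: a 2.6-fold lower number from compound 1 to compound 2 (0.41 log units; beyond the scatter), and a 4.5-fold higher number from compound 1 to compound 3 (0.65 log units; beyond the scatter). They show that one small group on that ring can move the number modestly in either direction, and that the position occupied in compound 3 is the one where the methyl hurt. Nothing measured distinguishes chloro from methyl there, so compound 4 is expected to stay close to compound 3, with a step of a 1.5-fold lower number from compound 3 to compound 4 (0.19 log units; within the scatter). Compound 4 is estimated at 250 nM, within a range of 80 nM to 800 nM.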

Compound 4, inhibition constant: 826 nM
Estimate against measurement, compound 4: 3.3-fold (0.52 log units) below; the measured number lies above the stated range.
By their numbers in this assay, from the lowest: compound 2; then compound 1; then compound 3; then compound 4.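

In this assay, the swap of methyl for chloro on this aromatic carbon, meta to a large group, is not neutral: it gives a 2.2-fold higher number from compound 3 to compound 4 (0.33 log units; beyond the scatter), so two groups of one heavy atom each, neither with a hydrogen-bond donor or acceptor, can still be told apart at this position. Set against the unsubstituted parent, chloro gives a 9.7-fold higher number from compound 1 to compound 4 (0.99 log units; beyond the scatter), while methyl at the same position gave a 4.5-fold higher number from compound 1 to compound 3 (0.65 log units; beyond the scatter), so both groups raise the number here and chloro raises it further, which makes this position look less tolerant than the methyl alone could show. No independent measurement is available to say what lies behind the difference between the two groups.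

The compounds shown leave open whether a chloro would lower the number where compound 2 carries its methyl, as that methyl did, or would raise it as it does in compound 4. They also leave open how other groups at the position shared by compound 3 and compound 4 would behave, such as a fluoro, a methoxy or an amine.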